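Replacing pentyl with methoxy in the series

This account rests on a few compounds, and the source may have more. Where it says the series, first, only, none or still open, it means among the compounds named here.

In a functional assay on MGC-803 cells (Homo sapiens) for inhibition, read by MTT assay, with a stated time of 72 h (on this read-out higher numbers stand for weaker inhibition and lower numbers for stronger inhibition), compound 1 (`CCCc1ccc(NC(=O)C2CCN(C/C=C/c3ccccc3)CC2)cc1`) gives 5210 nM and compound 2 (`CCCCCc1ccc(NC(=O)C2CCN(C/C=C/c3ccccc3)CC2)cc1`) gives 2550 nM. For the measured compounds named here, compound 2 thus holds the lowest of the two numbers so far. The next structure is compound 3 (`COc1ccc(NC(=O)C2CCN(C/C=C/c3ccccc3)CC2)cc1`), with this change: methoxy in place of pentyl on an aromatic carbon. Methoxy stands in place of pentyl on an aromatic carbon, para to a large group.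

Going by the values given here, only one measured step bears on this, and only indirectly: a 2.0-fold lower number from compound 1 to compound 2 (0.31 log units; beyond the scatter). It is modest, lies beyond the scatter and goes with a longer chain. Among the compounds with values here, no measured step involves methoxy, and two compounds do not establish a trend. Even so, the shorter chain of compound 1, at 5210 nM, suggests that losing the pentyl chain should raise the number in this assay. The expected change is a 2.9-fold higher number from compound 2 to compound 3 (0.47 log units; beyond the scatter), a moderate move towards weaker inhibition, with considerable uncertainty. For compound 3 the estimate is 7500 nM, with an expected range of 3000 nM to 18000 nM.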

Compound 3, half-maximal inhibitory concentration: 58200 nM
The estimate for compound 3 lay 7.8-fold (0.89 log units) below the measured number; the measured number lies above the stated range.
By their numbers in this assay, from the lowest: compound 2; then compound 1; then compound 3.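

At this position, on an aromatic carbon para to a large group, the choice of group matters far more than the two alkyl compounds alone could show: in this assay methoxy in place of pentyl gives a 23-fold higher number from compound 2 to compound 3 (1.36 log units; beyond the scatter) and so outweighs the modest 2.0-fold lower number from compound 1 to compound 2 (0.31 log units; beyond the scatter) seen between the chains. Methoxy in place of propyl also gives an 11-fold higher number from compound 1 to compound 3 (1.05 log units; beyond the scatter) as a large step, so the rise does not depend on pentyl being the group that leaves, and compound 3 holds the highest number of the three. Nothing measured on these compounds accounts for the size of this rise.

Methoxy differs from both alkyl groups in two ways at once, with fewer heavy atoms and an oxygen carrying a hydrogen-bond acceptor, and these compounds cannot separate the two. Butoxy, a chain close to pentyl in length that still carries the oxygen, would bear on that question, while a longer chain such as heptyl would show whether the modest gain from propyl to pentyl continues.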